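The compounds below may be only part of what the source reports. "The series", "measured", "known", "first", "only" and "open" are said of these compounds alone.

Measured in a functional assay on SGC-7901 cells (Homo sapiens) for antiproliferative activity, read by MTT assay, with a stated time of 48 h (on this read-out higher numbers stand for weaker inhibition and lower numbers for stronger inhibition), so far:

- compound 1 `Cc1ccccc1-c1nnc(SCc2ccc(Cl)nc2)o1` gives 8.51 ug/mL
- compound 2 `COc1ccccc1-c1nnc(SCc2ccc(Cl)nc2)o1` gives 8.2 ug/mL
- compound 3 `CN(C)c1ccc(-c2nnc(SCc3ccc(Cl)nc3)o2)cc1` gives 8.9 ug/mL

These three values sit close together. Compound 1 lies within the scatter of both compound 2 and compound 3, so no order can be read among them, and it serves as a fair reference point.

The next compound to be tested is compound 4 `Clc1ccc(CSc2nnc(-c3ccccn3)o2)cn1`, which has no value yet. It carries pyridin-2-yl in place of 2-methylphenyl on an aromatic carbon of a five-membered aromatic ring with 2 nitrogen and 1 oxygen (pyridin-2-yl in place of 2-methylphenyl on an aromatic carbon).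

Among the compounds with values here, only one measured step bears on this change. Methoxy in place of methyl on an aromatic carbon gave a 1.0-fold lower number from compound 1 to compound 2 (0.02 log units; within the scatter), which is within the scatter. Compound 3, with a different group again, shows 8.9 ug/mL and stays in the same range. Within the data shown here, none of the measured compounds has a hetero atom in this ring, however, so the change itself remains untested. In this assay a shift beyond the scatter is therefore not expected, in either direction, though the range has to stay generous.

The expected step is a 1.0-fold lower number from compound 1 to compound 4 (0.00 log units; within the scatter), which is no real change. For compound 4 the estimated value is 8.5 ug/mL, with an expected range from 4.5 ug/mL to 16 ug/mL.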

Compound 4, half-maximal inhibitory concentration: 12.6 ug/mL
Compound 4: the middle estimate sits 1.5-fold (0.17 log units) below what was measured; the range from low to high includes it.
By their numbers in this assay, from the lowest: compounds 2, 1, 3 and 4 (each within the scatter of the next).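

In this assay, pyridin-2-yl in place of 2-methylphenyl on this aromatic carbon of the five-membered ring gives a 1.5-fold higher number from compound 1 to compound 4 (0.17 log units; within the scatter), so a step that cannot be told from repeat measurement. This is the first compound shown with a hetero atom in the six-membered aromatic ring at this place, and the first whose group here is counted with a hydrogen-bond acceptor, and neither difference produces a shift that can be read. Nothing measured here speaks to what lies behind this result, and the small step itself calls for no explanation.

The compounds shown leave open whether a group of another kind at this carbon, such as a carboxylic acid or a longer alkyl chain in place of the aromatic ring, would move the number beyond the scatter in either direction. They also leave open whether pyridin-4-yl would behave as pyridin-2-yl does here, since a single nitrogen-bearing ring cannot show whether the result holds for such rings in general.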